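Heteroaryl ketones: oxadiazole to thiadiazole on the carbonyl carbon

The source may hold more compounds than are shown below. What is called first, only, known or untested is meant among the compounds shown, and "the series" means these compounds.

compound 1 `O=C(CCCCCCc1ccccc1)c1ncno1` — 25000 nM
compound 2 `O=C(CCCCCCc1ccccc1)c1ncon1` — > 100000 nM (a limit)
compound 3 `O=C(CCCCCCc1ccccc1)c1nncs1` — not yet measured

All numbers come from an assay on isolated protein for inhibition of neutral cholesterol ester hydrolase 1 (Homo sapiens); on this read-out higher numbers stand for weaker inhibition and lower numbers for stronger inhibition. Compound 1 gives 25000 nM. For compound 2 the assay returns only a limit, > 100000 nM, so its true position is not known. Among the measured compounds shown here, the one measured step, an at least 4.0-fold higher number from compound 1 to compound 2 (0.60 log units; beyond the scatter), is itself bounded by the limit of > 100000 nM in this assay, at which 1 of the 2 values shown sits; it shows that moving the attachment point of the oxadiazole weakens inhibition, but not by how much.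

Compound 3 differs from compound 2 by 1,3,4-thiadiazol-2-yl in place of 1,2,4-oxadiazol-3-yl on a carbonyl carbon. For the measured compounds named here, no measured step changes the ring heteroatom, so the size of this step is not covered by the data; the measured step only shows that this position is sensitive to the heteroaryl group. Compound 3 is therefore expected near 40000 nM, in the range 8000 nM to 200000 nM. That estimate implies an expected step of an at least 2.5-fold lower number from compound 2 to compound 3 (0.39 log units; beyond the scatter), with a real chance that the assay again reports only a limit.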

Compound 3, half-maximal inhibitory concentration: > 100000 nM
Compound 3: only a limit was reported (the forecaster's own chance of this, stated with the estimate: 40%); middle value at least 2.5-fold (0.39 log units) away from the limit.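

In this assay, putting 1,3,4-thiadiazol-2-yl in place of 1,2,4-oxadiazol-5-yl on the carbonyl carbon gives an at least 4.0-fold higher number from compound 1 to compound 3 (0.60 log units; beyond the scatter). This extends the sensitivity of this position beyond the oxadiazole attachment point: a ring carrying sulfur also gives no gain over compound 1, which remains the only one of the three with a value that is not a limit. The step from compound 2 to compound 3 cannot be read, and the series now rests largely on one limit: the limit of > 100000 nM in this assay, at which 2 of the 3 values shown sit.

From the compounds shown here alone, compound 1 and compound 3 differ in both the ring heteroatom and its arrangement, so the share of the sulfur atom alone stays open. Also open, going by these compounds, is whether a pyridin-2-yl ring or a carboxylic acid on the carbonyl carbon would give a lower number than compound 1 at 25000 nM.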